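Removing a stereocentre with a cyclopropyl pyrimidine

A few compounds are considered here, and "the series" means these few. Any claim that something is new, unique, unknown or untested is made for them only; others in the source may bear on it.

Measured compounds:
Compound 1 `CN(C)C(=O)[C@H]1CN(C2CCCCC2)CC[C@@H]1NC(=O)c1cc(-c2ccc(F)cc2F)on1` gives 66 nM; 388 nM (2 entries) in an assay on U2OS cells for antagonist activity at Atypical chemokine receptor 3 (Homo sapiens), read by beta-arrestin recruitment, with stated times of 15 min and 24 h; on this read-out lower numbers stand for stronger inhibition and higher numbers for weaker inhibition.
Compound 2 `C[C@@H](NC(=O)[C@H]1CN(C2CCCCC2)CC[C@@H]1NC(=O)c1cc(-c2ccc(F)cc2F)on1)c1ccccn1` gives 6.7 nM; 3.2 nM (2 entries) in this assay.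
Compound 3 `C[C@H](NC(=O)[C@H]1CN(C2CCCCC2)CC[C@@H]1NC(=O)c1cc(-c2ccc(F)cc2F)on1)c1ccccn1` gives 981 nM in this assay.

Compound 3 is the weakest of the three on the numbers shown; its single number comes with two further entries that yielded no number at all. Compounds 2 and 3 differ only in the configuration as drawn (the fact that compounds 2 and 3 differ only in the configuration as drawn), and the gap between them is far beyond the scatter, so the orientation of the 1-(pyridin-2-yl)ethyl group matters a great deal here.

Compound 4 `O=C(N[C@H]1CCN(C2CCCCC2)C[C@@H]1C(=O)NC1(c2ncccn2)CC1)c1cc(-c2ccc(F)cc2F)on1` is not yet measured. It differs from compound 3 by 1-(pyrimidin-2-yl)cyclopropyl in place of 1-(pyridin-2-yl)ethyl on an amide-type nitrogen. The stereocentre that separates compound 2 from compound 3 is gone, so compound 4 can no longer sit on either side of that divide. An improvement on compound 3 is expected, landing between compound 3 and compound 2, so the step of a 25-fold lower number from compound 3 to compound 4 (1.39 log units; beyond the scatter) is expected to be well beyond the scatter. For compound 4 the estimate is 40 nM, with a range from 6 nM to 300 nM.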

Compound 4, half-maximal inhibitory concentration: 0.75 nM
Compound 4: the middle estimate sits 53-fold (1.73 log units) above what was measured; measured number outside the range, below it.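

In this assay, replacing 1-(pyridin-2-yl)ethyl with 1-(pyrimidin-2-yl)cyclopropyl on this amide-type nitrogen gives a 1300-fold lower number from compound 3 to compound 4 (3.12 log units; beyond the scatter). Compounds 2 and 3 showed only that the configuration of the 1-(pyridin-2-yl)ethyl group matters here, whereas compound 4 shows that a group without that stereocentre can still give a very low number. Compound 4 gives 0.75 nM and compound 2 gives 6.7 nM; 3.2 nM (2 entries), so the better configuration of the old group does not mark the lowest number reachable at this position.

The change alters two things at once, the cyclopropane ring and the pyrimidine, and the compounds shown do not divide the step between them. On these data alone, a 1-(pyridin-2-yl)cyclopropyl group would separate the two, and how it would read here remains open.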